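From Hydroxy to Hydrogen on a Shared Macrocyclic Core

The source may hold more compounds than are shown below. What is called first, only, known or untested is meant among the compounds shown, and "the series" means these compounds.

The measured compounds:
compound 1, `CCCC[C@H]1CCCC[C@H](C)[C@@H](O[C@H]2OC[C@@H](O)[C@@H](O)[C@H]2O)c2cc(O)c(c(O)c2)[C@@H](CCCC)CCCC[C@H](C)[C@@H](O[C@@H]2OC[C@@H](O)[C@@H](O)[C@H]2O)c2cc(O)c1c(O)c2`, 600 nM
compound 2, `CCCC[C@H]1CCCC[C@H](C)[C@@H](O)c2cc(O)c(c(O)c2)[C@@H](CCCC)CCCC[C@H](C)[C@@H](O[C@@H]2OC[C@@H](O)[C@@H](O)[C@H]2O)c2cc(O)c1c(O)c2`, 600 nM

Among the compounds with values here, in a functional assay on MDA-MB-435 cells (Homo sapiens) for antiproliferative activity (a lower number here means a stronger inhibitor, a higher number a weaker inhibitor), compound 2 gives 600 nM and stands level with compound 1, which gives 600 nM; the one measured step, no change at the digits printed from compound 1 to compound 2 (within the scatter), took a whole sugar off an oxygen on a saturated carbon without moving the read-out beyond the scatter.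

Compound 3, `CCCC[C@H]1CCCC[C@H](C)Cc2cc(O)c(c(O)c2)[C@@H](CCCC)CCCC[C@H](C)[C@@H](O[C@@H]2OC[C@@H](O)[C@@H](O)[C@H]2O)c2cc(O)c1c(O)c2`, differs from compound 2 in one place: hydrogen in place of hydroxy on a saturated ring carbon. Within the data shown here, the oxygen that is lost here is the one that in compound 1 carried the sugar, so no change at the digits printed from compound 1 to compound 2 (within the scatter) is the step that bears on this change, and it was flat. Among the measured compounds shown here, no measured step removes the hydroxy itself, so the expectation rests on that flat step alone. Compound 3 is therefore expected to give 600 nM, with a range from 250 nM to 1500 nM. This corresponds to an expected step of no change at the digits printed from compound 2 to compound 3 (within the scatter), that is, none beyond the scatter.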

Compound 3, half-maximal inhibitory concentration: 600 nM
For compound 3 middle estimate and measured number coincide at the digits printed; the measured number falls inside the stated range.
By their numbers in this assay, from the lowest: compounds 1, 2 and 3 (each within the scatter of the next).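

In this assay, within the data shown here, the hydroxy on this saturated ring carbon can be replaced by hydrogen with no effect beyond the scatter (no change at the digits printed from compound 2 to compound 3 (within the scatter)), which the earlier compounds did not show, since compound 2 still kept that oxygen. Removing the sugar together with the oxygen that carried it also leaves the read-out flat (no change at the digits printed from compound 1 to compound 3 (within the scatter)), so at this position neither the sugar nor the oxygen is needed to hold the antiproliferative value seen for compound 1. No evidence is available to explain why this position tolerates these changes.

The compounds shown leave open whether a larger or different group at this carbon, such as an amine or a methoxy group, would be tolerated equally. They also leave open whether the value would hold if the sugar that all three compounds retain were removed.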